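A Ring Exchange on an Aromatic Carbon

The source may report more compounds than this note shows. Statements on the series, on what has been measured and on what is new or still open speak of the compounds shown alone.

In an ADME assay on microsomes from liver (Mus musculus) for metabolic stability, read by LC-MS, using NADPH, with stated times of 15 min and 60 min, tested at 4.6 uM (a lower number here means that the compound disappears faster, a higher number that the compound lasts longer), compound 2 `CN1CCC(c2ccc3c(c2)oc(=O)n3C(=O)NCCCCc2ccccc2)CC1` gives 0.667 h, and compound 1 `CC(C)N1CCC(c2ccc3c(c2)oc(=O)n3C(=O)NCCCCc2ccccc2)CC1` gives 1 h. For the measured compounds named here, the only measured step, a 1.5-fold lower number from compound 1 to compound 2 (0.18 log units; within the scatter), puts methyl in place of isopropyl on an amine nitrogen in a ring, so the two compounds do not stand apart. Compound 3 `CN1CCN(c2ccc3c(c2)oc(=O)n3C(=O)NCCCCc2ccccc2)CC1=O` keeps the shared core but carries 4-methyl-3-oxopiperazin-1-yl in place of 1-methylpiperidin-4-yl on an aromatic carbon. The measured step does not cover an exchange of this kind and offers only a weak guide. Starting from compound 2 at 0.667 h, no change beyond the scatter is expected, and the range is kept wide. The expected change is a 1.2-fold higher number from compound 2 to compound 3 (0.08 log units; within the scatter). The estimate in this assay for compound 3 is 0.8 h, within a range from 0.3 h to 2 h.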

Compound 3, half-life: 0.5 h
The estimate for compound 3 lay 1.6-fold (0.20 log units) above the measured number, within the range that was stated.
By their numbers in this assay, from the lowest: compounds 3, 2 and 1 (each within the scatter of the next).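

Until now only the group on the ring nitrogen had changed, whereas here the whole ring on the aromatic carbon is exchanged, and in this assay this larger change still gives only a 1.3-fold lower number from compound 2 to compound 3 (0.13 log units; within the scatter). Even the pair furthest apart, which also differs in this one place, shows a 2.0-fold lower number from compound 1 to compound 3 (0.30 log units; within the scatter), so the three compounds cannot be told apart in this assay, although 4-methyl-3-oxopiperazin-1-yl brings a second ring hetero atom and a double bond outside aromatic rings. No supporting measurement bears on this result, so it stays a plain observation.

All three groups here are six-membered non-aromatic rings with a nitrogen. From the compounds shown here alone, whether a morpholine ring, an open-chain dimethylamino group or a carboxylic acid on this aromatic carbon would also stay within the scatter remains open.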